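Fluoro for chloro on the aryl group across two cores

The compounds below may be only part of what the source reports. "The series", "measured", "known", "first", "only" and "open" are said of these compounds alone.

Compound 1 `Cc1cc(C)c2c(O)cc(-c3cccc(F)c3)nc2n1` and compound 2 `Cc1cc(C)c2c(O)cc(-c3cccc(Cl)c3)nc2n1` share one core and differ only in the aryl halogen. In a functional assay on SK-MEL-5 cells (Homo sapiens) for antiproliferative activity (a higher number here means a weaker inhibitor of growth, a lower number a stronger inhibitor of growth), compound 1 gives 37.2 nM, and compound 2 gives 117 nM. The exchange fluoro in place of chloro on an aromatic carbon produces a 3.1-fold lower number from compound 2 to compound 1 (0.50 log units; beyond the scatter). Compound 3 `Cc1cnc2[nH]c(-c3cccc(Cl)c3)cc(=O)c2c1` carries the chloro aryl group on a second core; in this assay compound 3 gives 70.8 nM, a value within the scatter of both compound 2 and compound 1. How the two cores differ is not broken down here. Compound 4 `Cc1cnc2[nH]c(-c3cccc(F)c3)cc(=O)c2c1` applies the same change to compound 3: fluoro in place of chloro on an aromatic carbon. The place is the same word for word, so this is the same change. Going by the values given here, the expected step of a 2.5-fold lower number from compound 3 to compound 4 (0.40 log units; beyond the scatter) is set beside the measured one because a 3.1-fold lower number from compound 2 to compound 1 (0.50 log units; beyond the scatter) is the only guide, widened for the change of core. Compound 4 is therefore estimated at 28 nM in this assay, between 12 nM and 70 nM.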

Compound 4, concentration for 50% growth inhibition: 28.2 nM
For compound 4 the middle estimate is 1.0-fold (0.00 log units) below the measured one; measured number inside the range.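

In this assay, fluoro in place of chloro on an aromatic carbon gives a 2.5-fold lower number from compound 3 to compound 4 (0.40 log units; beyond the scatter). Set beside the step on the core of compound 1, the change carries over to the second core in the same direction, and the two steps cannot be told apart in size: the same change on two cores in this assay, a 3.1-fold lower number (0.50 log units; beyond the scatter) from compound 2 to compound 1 and a 2.5-fold lower number (0.40 log units; beyond the scatter) from compound 3 to compound 4, 1.3-fold (0.10 log units) apart, within the scatter of two such steps

Going by these compounds alone, this rests on only two matched pairs in one cell assay, with the change in one place on the aryl group, so it does not show that the step would hold on a further core or in another place.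

Still open, as far as these compounds go, is whether other groups in the same place, such as methoxy, nitrile or an amine, would behave alike on both cores. Equally open, from the compounds shown here alone, is whether a hydrogen there would fall in line with the two halogens.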